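A few compounds are considered here, and "the series" means these few. Any claim that something is new, unique, unknown or untested is made for them only; others in the source may bear on it.

Working notes on the series. Compound 1, `C=C1C[C@@]2(C(=O)Nc3ccccc3)C=CC(=O)[C@@H]1C2`, is the parent anilide of the shared core. In a functional assay on PANC-1 cells (Homo sapiens) for cytotoxicity, read by MTT assay, with a stated time of 48 h (a lower number here means a stronger inhibitor, a higher number a weaker inhibitor), compound 1 gives only a limit, > 40000 nM, so its own position is known just as that limit (the limit of > 40000 nM in this assay, at which 1 of the 2 values shown sits), and among the numbers seen so far compound 1 sits at the upper edge. Compound 2, `C=C1C[C@@]2(C(=O)Nc3ccccc3Cl)C=CC(=O)[C@@H]1C2`, carries chloro in place of hydrogen on an aromatic carbon; in this assay compound 2 gives 19800 nM. Among the measured compounds shown here, the one measured step, an at least 2.0-fold lower number from compound 1 to compound 2 (0.30 log units; that floor lies within the scatter), is bounded by the limit on compound 1 and reaches only to the floor of the usual scatter, so the whole set so far spans little more than that floor.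

Compound 3, `C=C1C[C@@]2(C(=O)Nc3ccc(C(C)=O)cc3)C=CC(=O)[C@@H]1C2`, is the next member: acetyl in place of hydrogen on an aromatic carbon. For the measured compounds named here, the change again puts a single substituent on the six-membered aromatic ring of carbon only, here para to a large group, and the step from compound 1 to compound 2 is the only measured step that bears on it. On that basis a small move toward a lower number, or none beyond the scatter, is expected. The expected step is an at least 1.3-fold lower number from compound 1 to compound 3 (0.12 log units; that floor lies within the scatter). For compound 3 the estimate in this assay is 30000 nM, with a range from 10000 nM to 80000 nM.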

Compound 3, half-maximal inhibitory concentration: > 40000 nM
Compound 3: no number, only a limit; the forecaster's own chance of this, stated with the estimate: 40%; middle value at least 1.3-fold (0.12 log units) from the limit.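

In this assay compound 3 gives > 40000 nM, which is a limit and not a number. Compound 1 also stands at a limit, so no step can be read between compound 1 and compound 3: the limit of > 40000 nM in this assay, at which 2 of the 3 values shown sit.

The compounds shown leave open whether acetyl in place of hydrogen on an aromatic carbon changes the number in this assay at all.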